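A few compounds are considered here, and "the series" means these few. Any claim that something is new, unique, unknown or untested is made for them only; others in the source may bear on it.

Measured so far in a functional assay on A549 cells (Homo sapiens) for inhibition, read by MTT assay, with a stated time of 24 h; a higher number here means a weaker inhibitor of growth, a lower number a stronger inhibitor of growth:

Compound 1 `Cn1cc(-c2nc3ccccc3n2C(=O)c2ccccc2)c2ccccc21` gives 19600 nM
Compound 2 `COc1ccccc1C(=O)n1c(-c2cn(C)c3ccccc23)nc2ccccc21` gives 12300 nM

Among the compounds with values here, compound 1 has only one measured neighbour, compound 2, and the two values lie within the scatter of each other, so neither can be ranked above the other. Compound 3 `COc1cccc(C(=O)n2c(-c3cn(C)c4ccccc34)nc3ccccc32)c1` has not been measured yet. It keeps the core of compound 1 and differs in one place, phenyl to 3-methoxyphenyl, meta to a large group. The counted change is methoxy in place of hydrogen on an aromatic carbon and in words it is methoxy in place of hydrogen on an aromatic carbon.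

Within the data shown here, only one measured step bears on this, the same kind of swap in compound 2. That step reads a 1.6-fold lower number from compound 1 to compound 2 (0.20 log units; within the scatter) and so gives no sign of a real shift. With this single small step as the guide, no change beyond the scatter is expected in this assay for compound 3. The estimated step is a 1.4-fold lower number from compound 1 to compound 3 (0.15 log units; within the scatter) and it stays modest. For compound 3 the expected value is 14000 nM (estimated range 7000 nM to 28000 nM).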

Compound 3, concentration for 50% growth inhibition: 10200 nM
Beside the measured number, compound 3's estimate is 1.4-fold (0.14 log units) above it; the range from low to high includes it.
By their numbers in this assay, from the lowest: compounds 3, 2 and 1 (each within the scatter of the next).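

In this assay, within the data shown here, the swap of phenyl for 3-methoxyphenyl gives a 1.9-fold lower number from compound 1 to compound 3 (0.28 log units; within the scatter), so a methoxy at this second place on the ring, like the one in compound 2, produces no shift that can be told apart from the ordinary scatter of repeated measurements. Moving the methoxy gives a 1.2-fold lower number from compound 2 to compound 3 (0.08 log units; within the scatter), so among these compounds the choice between 2-methoxyphenyl and 3-methoxyphenyl makes no readable difference, and all three values remain in one band. No supporting measurement is available that could explain why these values lie so close together.

From the compounds shown here alone, it remains open whether a different group on this ring, such as an amine, a carboxylic acid or a longer chain like butoxy, would move the number beyond the scatter. It is also unknown whether changes elsewhere on the shared core, for example replacing the methyl on its nitrogen with a longer chain, would have a larger effect in this assay than the methoxy swaps do.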